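The compounds below may be only part of what the source reports. "The series", "measured", "known", "first", "only" and "open" are said of these compounds alone.

Measured compounds:
- Compound 3 `CC(C)Cc1ccc(C(C)C(=O)NCc2ccccc2Cl)cc1`: 4100 nM
- Compound 1 `CC(C)Cc1ccc(C(C)C(=O)NCc2ccc(Cl)cc2)cc1`: 27000 nM
- Compound 2 `CC(C)Cc1ccc(C(C)C(=O)NCc2cccc(C(F)(F)F)c2)cc1`: 28000 nM

In an assay on brain for inhibition of Fatty-acid amide hydrolase 1 (Rattus norvegicus), read by scintillation counting, with a stated time of 10 min (a higher number here means a weaker inhibitor, a lower number a stronger inhibitor), compound 3 gives the lowest number of the three, with compound 1 nearest and compound 2 furthest. Compound 1 and compound 2 lie within the scatter of each other, so nothing separates them. Going by the values given here, the only single-change step in the set is a 6.6-fold lower number from compound 1 to compound 3 (0.82 log units; beyond the scatter), which moves the chloro group on the benzyl ring and lowers the number beyond the scatter.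

Compound 4 `CC(C)Cc1ccc(C(C)C(=O)NCc2cc(Cl)ccc2Cl)cc1` has not yet been measured in this assay. It differs from compound 3 by chloro in place of hydrogen on an aromatic carbon; read one bond further out, 2-chlorophenyl becomes 2,5-dichlorophenyl. Among the compounds with values here, no measured step adds a second substituent to this ring, so the step from compound 1 to compound 3 bears only loosely: it shows the ring position of the chloro matters, not what a further chloro does. With the 2-chloro kept, the added chloro is expected to change the number little, a 1.4-fold lower number from compound 3 to compound 4 (0.14 log units; within the scatter), likely within the scatter. Compound 4 is therefore estimated at 3000 nM, with a range of 1000 nM to 9000 nM.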

Compound 4, half-maximal inhibitory concentration: 4400 nM
The estimate for compound 4 lay 1.5-fold (0.17 log units) below the measured number; low and high end bracket the measured number.
By their numbers in this assay, from the lowest: compounds 3 and 4 (each within the scatter of the next); then compounds 1 and 2 (each within the scatter of the next).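

In this assay, a chloro in place of hydrogen on the ring of compound 3, meta to a large group and para to a chloro group, gives no change that can be told from scatter (a 1.1-fold higher number from compound 3 to compound 4 (0.03 log units; within the scatter)). The 2,5-dichlorophenyl group still separates from the 4-chlorophenyl group (a 6.1-fold lower number from compound 1 to compound 4 (0.79 log units; beyond the scatter)), so this site accepts a second chloro without loss of the difference first seen with the 2-chlorophenyl group. Nothing measured on these compounds accounts for this result.

Open, going by these compounds, is whether this ring carbon accepts a group other than chloro, such as an amine, a carboxylic acid or a methoxy group, with the 2-chloro kept. Also open, on these data alone, is how the same added chloro reads on a ring without the 2-chloro.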